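Shared-core series: half-life notes on the bromo-to-methoxy step

The compounds below may be only part of what the source reports. "The series", "measured", "known", "first", "only" and "open" are said of these compounds alone.

Three compounds on a shared core have been run in a physicochemical assay for pharmacokinetics; a higher number here means that the compound lasts longer, a lower number that the compound disappears faster. Compound 1 `O=C(CCc1ccccc1)N1C(=O)c2ccccc2S1(=O)=O` returns in this assay only a limit of the assay, > 5.77 h. Compound 3 `O=C(Oc1ccccc1)N1C(=O)c2ccccc2S1(=O)=O` also returns in this assay only a limit, > 3.04 h. Compound 2 `O=C(NCc1cccc(Br)c1)N1C(=O)c2ccccc2S1(=O)=O` likewise returns in this assay only a limit, > 166 h. Where compound 2 stands among these numbers is therefore open: every value shown sits at a limit of the measurement (the limit of > 166 h in this assay, at which 1 of the 3 values shown sits, (the limit of > 3.04 h in this assay, at which 1 of the 3 values shown sits), (the limit of > 5.77 h in this assay, at which 1 of the 3 values shown sits)), so no order between the three compounds can be read, and no step between measured compounds is available to calibrate the series.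

Compound 4 `COc1cccc(CNC(=O)N2C(=O)c3ccccc3S2(=O)=O)c1` is the unmeasured partner of compound 2. The change from compound 2 to compound 4 is methoxy in place of bromo on an aromatic carbon. Among the measured compounds shown here, with no measured step to lean on, the expectation in this assay is a step from compound 2 to compound 4 of a number no higher from compound 2 to compound 4 (the limit leaves the size open), that is, nothing beyond the scatter in either direction. Compound 4 is accordingly estimated at 166 h in this assay, within a range from 60 h to 400 h, and most probably it will again be reported as a limit rather than as a number.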

Compound 4, half-life: > 166 h
Compound 4: a limit, no number (the forecaster's own chance of this, stated with the estimate: 75%); the middle value sits exactly at the limit.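

In this assay compound 4 returns only a limit, > 166 h. Compound 2 also returns only a limit, so no step from compound 2 to compound 4 can be read: the limit of > 166 h in this assay, at which 2 of the 4 values shown sit.

From the compounds shown here alone, the actual half-lives of compound 1, compound 2, compound 3 and compound 4 stay open, as do any order among them and the size of the bromo-to-methoxy step.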